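The compounds below may be only part of what the source reports. "The series", "measured", "known", "first", "only" and "open" are said of these compounds alone.

Working notes on the series. Compound 1 `COc1ccc(F)cc1N1C(=O)CSC1c1cccc(C(=O)NCCCCn2cccn2)c1` in a functional assay on HOS-TE85 cells (Homo sapiens) for inhibition, read by CCK-8 assay, with a stated time of 72 h (on this read-out lower numbers stand for stronger inhibition and higher numbers for weaker inhibition), gives 97.3 nM, the highest of the two plain numbers in hand; compound 2 `O=C(NCCCCc1ccccc1)c1cccc(C2SCC(=O)N2c2ccccn2)c1` gives 19.7 nM. Compound 3 `COc1ccc(OC)c(N2C(=O)CSC2c2cccc(C(=O)NCCCCc3ccccc3)c2)c1` returns only a limit, > 1000 nM, and the limit of > 1000 nM in this assay, at which 1 of the 3 values shown sits, marks it as such. Among the measured compounds shown here, the one measured step at the ring-nitrogen substituent, an at least 50-fold higher number from compound 2 to compound 3 (1.70 log units; beyond the scatter), was large, toward weaker inhibition. Compound 4 `CCOC(=O)c1sc(N2C(=O)CSC2c2cccc(C(=O)NCCCCn3cccn3)c2)nc1C` carries the change 5-(ethoxycarbonyl)-4-methyl-1,3-thiazol-2-yl in place of 5-fluoro-2-methoxyphenyl on an amide-type nitrogen in a ring at that same position. That single step bears on it but gives no direction for a thiazole replacing a phenyl, so a shift beyond the scatter is expected in this assay, with weaker inhibition more likely than stronger. Compound 4 is therefore estimated at 300 nM, within 60 nM to 1500 nM, a step of a 3.1-fold higher number from compound 1 to compound 4 (0.49 log units; beyond the scatter).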

Compound 4, half-maximal inhibitory concentration: 430 nM
For compound 4 the middle estimate is 1.4-fold (0.16 log units) below the measured one; the measured number falls inside the stated range.
By their numbers in this assay, from the lowest: compound 2; then compound 1; then compound 4. At a limit, above all of these: compound 3.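

In this assay, the replacement of 5-fluoro-2-methoxyphenyl by 5-(ethoxycarbonyl)-4-methyl-1,3-thiazol-2-yl gives a 4.4-fold higher number from compound 1 to compound 4 (0.65 log units; beyond the scatter), so this position now has a direction for a thiazole replacing a phenyl: toward weaker inhibition. The step is modest, and compound 4 still reads as a plain number. Compound 3 remains the only limit in the set: the limit of > 1000 nM in this assay, at which 1 of the 4 values shown sits.

This single step changes the ring and its substituents together, so the shift cannot be assigned to either. From the compounds shown here alone, how an unsubstituted thiazol-2-yl, or a carboxylic acid in place of the ethyl ester, would read stays open.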